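Swapping the Benzyl Group on Compound 2

The source may report more compounds than this note shows. Statements on the series, on what has been measured and on what is new or still open speak of the compounds shown alone.

Compound 1 `CCCCc1ccc2c(c1)C(=O)C(=O)N2` is the simplest of the three. In a functional assay on HepG2 cells (Homo sapiens) for antiproliferative activity, read by MTT assay, with a stated time of 48 h (a lower number here means a stronger inhibitor, a higher number a weaker inhibitor), compound 1 gives only a limit, > 10000 nM. For the measured compounds named here, compound 2 `COc1ccc(-c2ccc3c(c2)C(=O)C(=O)N3Cc2ccc(Cl)c(Cl)c2)cc1` carries a 3,4-dichlorobenzyl group on the amide-type nitrogen in a ring; in this assay compound 2 gives 990 nM, the only true number measured so far. The other value shown is the limit of > 10000 nM in this assay, at which 1 of the 2 values shown sits. Compound 3 `COc1ccc(-c2ccc3c(c2)C(=O)C(=O)N3Cc2ccccc2OC)cc1` differs from compound 2 in one place: 2-methoxyphenyl in place of 3,4-dichlorophenyl on a saturated chain carbon bound to an amide-type nitrogen in a ring. Going by the values given here, no measured pair isolates this change, so its direction is not fixed by the data. A modest loss of potency, somewhat beyond the usual scatter, is expected from compound 2 to compound 3, a 2.5-fold higher number from compound 2 to compound 3 (0.40 log units; beyond the scatter). For compound 3 the estimated value in this assay is 2500 nM, with a likely range from 800 nM to 8000 nM.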

Compound 3, half-maximal inhibitory concentration: 130 nM
Compound 3: the middle estimate sits 19-fold (1.28 log units) above what was measured; measured number below the stated range.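

For the compounds shown here, this is the first measured comparison at this place, on a saturated chain carbon bound to an amide-type nitrogen in a ring. In this assay, replacing 3,4-dichlorobenzyl with 2-methoxybenzyl gives a 7.6-fold lower number from compound 2 to compound 3 (0.88 log units; beyond the scatter) and makes compound 3 the stronger of this pair. The 3,4-dichlorophenyl group of compound 2 is therefore not required for this activity, and the activity can change clearly with this group alone, since the rest of the two structures is the same.

Going by these compounds, it remains open whether the gain comes from adding the methoxy group, from where it sits, or from losing the two chlorine atoms, and whether an amine, a carboxylic acid or a longer chain would be tolerated here. Nothing measured here explains the gain.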